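This account rests on a few compounds, and the source may have more. Where it says the series, first, only, none or still open, it means among the compounds named here.

In a functional assay on PC-3 cells (Homo sapiens) for cytotoxicity, read by MTT assay, with a stated time of 72 h (on this read-out lower numbers stand for stronger inhibition and higher numbers for weaker inhibition), three compounds with a shared core have been measured: compound 1 `O=C(/C=C/c1ccc([N+](=O)[O-])cc1)Nc1cc2c(Nc3ccc(F)c(Cl)c3)ncnc2cc1O[C@H]1CCOC1`, compound 2 `COc1ccc(/C=C/C(=O)Nc2cc3c(Nc4ccc(F)c(Cl)c4)ncnc3cc2O[C@H]2CCOC2)c(OC)c1` and compound 3 `COc1ccc(/C=C/C(=O)Nc2cc3c(Nc4ccc(F)c(Cl)c4)ncnc3cc2OC)c(OC)c1`. Compound 2 gives 2760 nM, the lowest number of the three. Compound 1 gives 22800 nM, and compound 3 gives 38500 nM.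

The next compound to be tested is compound 4 `COc1ccc(OC)c(/C=C/C(=O)Nc2cc3c(Nc4ccc(F)c(Cl)c4)ncnc3cc2O[C@H]2CCOC2)c1`, which differs from compound 2 in one group: 2,5-dimethoxyphenyl in place of 2,4-dimethoxyphenyl on a double-bonded chain carbon bound to a double-bonded chain carbon. Here, 2,5-dimethoxyphenyl takes the place of 2,4-dimethoxyphenyl on a double-bonded chain carbon bound to a double-bonded chain carbon. The two compounds have the same atoms, joined differently.

Two measured steps offer guidance. The modest step of an 8.3-fold lower number from compound 1 to compound 2 (0.92 log units; beyond the scatter) occurred at this same place, so changing the group here can shift the number, but it exchanged 4-nitrophenyl for a dimethoxyphenyl group. The large step of a 14-fold higher number from compound 2 to compound 3 (1.14 log units; beyond the scatter) occurred elsewhere, on an oxygen on an aromatic ring, and says little about this change. Among the measured compounds shown here, no measured pair shows the effect of changing only the arrangement of the dimethoxyphenyl group.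

A small rise in this assay is therefore expected, possibly no larger than the scatter. The expected change is a 1.4-fold higher number from compound 2 to compound 4 (0.16 log units; within the scatter). For compound 4, the estimated value is 4000 nM, with an expected range from 1300 nM to 13000 nM.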

Compound 4, half-maximal inhibitory concentration: 8730 nM
The estimate for compound 4 lay 2.2-fold (0.34 log units) below the measured number, and the stated range covers the measured number.
By their numbers in this assay, from the lowest: compound 2; then compound 4; then compounds 1 and 3 (each within the scatter of the next).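

In this assay, rearranging the same atoms within the dimethoxyphenyl group is enough to change the result, giving a 3.2-fold higher number from compound 2 to compound 4 (0.50 log units; beyond the scatter). So at this position the arrangement of the two methoxy groups on the ring counts, and not only their presence, which the earlier comparison of the 4-nitrophenyl and 2,4-dimethoxyphenyl groups could not separate. The 2,5-dimethoxyphenyl group still gives a 2.6-fold lower number from compound 1 to compound 4 (0.42 log units; beyond the scatter), a smaller gain than an 8.3-fold lower number from compound 1 to compound 2 (0.92 log units; beyond the scatter), and nothing available here explains why the two arrangements differ.

The compounds shown leave open how a phenyl ring with a single methoxy group, or with a hydroxyl or an amine in place of the methoxy groups, would behave at this position. From the compounds shown here alone, it also remains open whether the gap between the 2,4-dimethoxyphenyl and 2,5-dimethoxyphenyl groups would persist with methyl in place of oxolan-3-yl on the oxygen on the aromatic ring, as in compound 3.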